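A few compounds are considered here, and "the series" means these few. Any claim that something is new, unique, unknown or untested is made for them only; others in the source may bear on it.

Working notes on the amide series. In a physicochemical assay for lipophilicity, read by HPLC (on this read-out lower numbers stand for lower lipophilicity and higher numbers for higher lipophilicity), compound 1 `CCC(=O)N1CC[C@H](Nc2ncnc3c2nc(-c2cnc(C)nc2)n3CC)C1` gives 0.7 and compound 2 `CCn1c(-c2cnc(C)nc2)nc2c(N[C@H]3CCN(C(=O)C4CC4)C3)ncnc21` gives 0.8, so compound 2 has a single neighbour on these numbers and lies within the scatter of it. Compound 3 `CCn1c(-c2cnc(C)nc2)nc2c(N[C@H]3CCN(C(=O)c4cocn4)C3)ncnc21` has no value yet. The structural change is 1,3-oxazol-4-yl in place of cyclopropyl on a carbonyl carbon; in words, 1,3-oxazol-4-yl in place of cyclopropyl on a carbonyl carbon. For the measured compounds named here, one measured step bears on it, at the same kind of place: a number 0.10 log units higher from compound 1 to compound 2 (within the scatter), with cyclopropyl in place of ethyl. Going by the values given here, that step involves carbon groups only, so the data hold no direct precedent for a group with hetero atoms here. The entering group counts hydrogen-bond acceptors where cyclopropyl has none, so from compound 2 at 0.8 a small downward move in this assay is expected, though with little support. The expected step is a number 0.20 log units lower from compound 2 to compound 3 (within the scatter). For compound 3 the estimate is 0.6, with an expected range from 0.2 to 1.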

Compound 3, distribution coefficient: 0.6
Compound 3: middle estimate and measured number agree at the digits printed, within the range that was stated.
By their numbers in this assay, from the lowest: compounds 3, 1 and 2 (each within the scatter of the next).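

In this assay the place on a carbonyl carbon, whose other neighbour is an amide-type nitrogen in a ring, now has a reading for a group with hetero atoms: 1,3-oxazol-4-yl set against cyclopropyl gives a number 0.20 log units lower from compound 2 to compound 3 (within the scatter) and set against ethyl gives a number 0.10 log units lower from compound 1 to compound 3 (within the scatter) for the same change of group. For the compounds shown here, the earlier step compared carbon groups only, whereas these two steps take in a five-membered aromatic ring with 2 hetero atoms and 2 hydrogen-bond acceptors, and compounds 1, 2 and 3 still all lie within the scatter of one another, so no step at this place yet stands beyond the scatter. Nothing at hand gives a reason for these numbers.

Still open, as far as these compounds go, is whether any group on this carbonyl carbon gives a step beyond the scatter in this assay, for instance a primary amine on a short chain, a carboxylic acid, a longer chain such as n-hexyl, or a pyridine ring. From the compounds shown here alone, it is equally open whether 1,3-oxazol-4-yl would give a similar step on an amide elsewhere on the shared core.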